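A branched amine swap on a shared pyridylimidazole core

The source may report more compounds than this note shows. Statements on the series, on what has been measured and on what is new or still open speak of the compounds shown alone.

Compound 1 `CSc1nc(-c2ccc(F)cc2)c(-c2ccnc(NC3CCCCC3C)c2)[nH]1` was tested in a functional assay on blood (Homo sapiens) for inhibition (a higher number here means a weaker inhibitor, a lower number a stronger inhibitor), where compound 1 gives 136 nM. Among the compounds examined here it is the only one with a number: in this assay compound 2 `CSc1nc(-c2ccc(F)cc2)c(-c2ccnc(OCC3CCCO3)c2)[nH]1` is recorded as "not determined" (no result reported), and in this assay compound 3 `CSc1nc(-c2ccc(F)cc2)c(-c2ccnc(Sc3ccccc3)c2)[nH]1` is recorded as "not determined" (no result reported), so they offer no comparison and no step between measured compounds can be drawn.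

The next compound, compound 4 `CSc1nc(-c2ccc(F)cc2)c(-c2ccnc(NC(C)CCc3ccccc3)c2)[nH]1`, is built on the same core and differs from compound 1 in one place: 1-methyl-3-phenylpropyl in place of 2-methylcyclohexyl on a nitrogen on an aromatic ring. The nitrogen bearing the substituent and its aromatic neighbour are unchanged.

Among the compounds with values here, with only one measured value available, the expectation for compound 4 rests on compound 1 alone. The change is expected to move potency little, if at all, and the step of a 1.6-fold higher number from compound 1 to compound 4 (0.21 log units; within the scatter) is expected to lie within or just beyond the usual scatter, leaning toward a weaker inhibitor. Compound 4 is therefore estimated at 220 nM in this assay, with a plausible range from 60 nM to 800 nM.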

Compound 4, half-maximal inhibitory concentration: 2370 nM
Compound 4: the middle estimate sits 11-fold (1.03 log units) below what was measured, outside the stated range (above it).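

In this assay, putting 1-methyl-3-phenylpropyl in place of 2-methylcyclohexyl on the nitrogen gives a 17-fold higher number from compound 1 to compound 4 (1.24 log units; beyond the scatter), which shows that this position does not treat all branched carbon substituents alike. Neither group carries a hydrogen-bond donor, a hydrogen-bond acceptor or a net charge, so this large step accompanies a swap between two all-carbon groups, with a six-membered aromatic ring at the end of a chain replacing a six-membered non-aromatic ring. No evidence is available to explain the step.

The change alters the ring type, the chain and the size of the group together, and these two compounds cannot separate those features. A benzyl group, a cyclohexylmethyl group or a plain cyclohexyl group on the same nitrogen would be the kind of substituent needed to tell which feature goes with the step.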